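Hydrazone Variation on a Triazole Thioether Series

The source may report more compounds than this note shows. Statements on the series, on what has been measured and on what is new or still open speak of the compounds shown alone.

Measured so far:
- Compound 1 `Clc1ccccc1CSc1nnc(-c2ccncc2)n1-c1ccccc1` — 15700 nM
- Compound 2 `O=C(CSc1nnc(-c2ccncc2)n1-c1ccccc1)N/N=C/c1ccc(Br)cc1` — 5990 nM

Both compounds share a core carrying a pyridinyl group, a phenyl group and a thioether. In a functional assay on HepG2 cells (Homo sapiens) for inhibition, read by MTT assay, with a stated time of 48 h (a higher number here means a weaker inhibitor, a lower number a stronger inhibitor), compound 1 gives 15700 nM. Compound 2 extends the thioether through an amide into a hydrazone ending in a 4-bromophenyl group; in this assay compound 2 gives 5990 nM. Of the two numbers, compound 2 has the lower one, and the gap to compound 1 lies beyond the usual scatter, so compound 2 is the stronger inhibitor of the pair.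

Compound 3 `O=C(CSc1nnc(-c2ccncc2)n1-c1ccccc1)N/N=C/C=C/c1ccccc1` keeps the whole hydrazone arm of compound 2 and changes only its end group. The change is 2-phenylethenyl in place of 4-bromophenyl on a carbon with a double bond to nitrogen. Both groups bring one six-membered carbon ring; the newcomer adds a double bond outside aromatic rings and has no bromine. Going by the values given here, no measured pair shows the effect of such a swap, so the size of this step is open. In this assay the step of a 1.2-fold higher number from compound 2 to compound 3 (0.07 log units; within the scatter) is expected to stay close to the scatter, with no clear direction. Compound 3 is therefore estimated at 7000 nM, within 2500 nM to 20000 nM.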

Compound 3, half-maximal inhibitory concentration: 8280 nM
The estimate for compound 3 lay 1.2-fold (0.07 log units) below the measured number, and the stated range covers the measured number.
By their numbers in this assay, from the lowest: compounds 2, 3 and 1 (each within the scatter of the next, the first and the last beyond it).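

In this assay, exchanging the end group of the hydrazone arm gives a 1.4-fold higher number from compound 2 to compound 3 (0.14 log units; within the scatter) and so does not separate these two end groups. Going by these compounds alone, compounds 2 and 3 are the only pair here that differ in one place, so this is the only direct reading of this position: losing the bromine and gaining a double bond outside aromatic rings, while keeping one six-membered aromatic ring of carbon only, leaves the two numbers within the scatter of each other. No supporting measurement bears on why these two end groups read alike, so the finding remains an observation about this one pair.

The exchange bundles two differences, and a plain phenyl group in the same place would be needed to tell the bromine's contribution from that of the added double bond. Going by these compounds, both end groups also carry an aromatic ring of carbon, so it remains open how an end group without one, such as an amine or a carboxylic acid, would read in this assay.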